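Swapping Ethoxy for Methyl on a Diaminotriazine Aryl

A few compounds are considered here, and "the series" means these few. Any claim that something is new, unique, unknown or untested is made for them only; others in the source may bear on it.

Measured so far:
compound 1, `CCOc1ccccc1-c1nc(N)nc(N)n1`: -5%
compound 2, `Nc1nc(N)nc(-c2cccc(C(F)(F)F)c2)n1`: 81%
compound 3, `Nc1nc(N)nc(-c2cc(Cl)ccc2Br)n1`: 81%

In a functional assay on the whole organism with Rattus norvegicus as the target, at a dose of 20 mg/kg by the intraperitoneal route (a lower number here means less inhibition, a higher number more inhibition at the dose given (going by the name of the read-out)), compound 1 gives the lowest of the three numbers, far below compound 2 and compound 3, both beyond the usual scatter. Compound 4, `Cc1ccccc1-c1nc(N)nc(N)n1`, has not yet been measured. It differs from compound 1 in one place: methyl in place of ethoxy on an aromatic carbon. Among the measured compounds shown here, no measured pair shows this change, so its size cannot be read from the data. Given the wide spread seen among the three measured compounds, a step of a number 25 percentage points higher from compound 1 to compound 4 (beyond the scatter) is expected, but the direction is uncertain. Compound 4 is estimated to give 20%, within a range from -15% to 60% in this assay.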

Compound 4, a percentage reported as inhibition, in the whole organism at one dose (the size of the read-out at that dose, not a potency) in the Rattus norvegicus assay: 28%
Compound 4: middle estimate off by 8 percentage points, on the low side; measured number inside the range.
By their numbers in the Rattus norvegicus assay, from the lowest: compound 1; then compound 4; then compounds 2 and 3 (each within the scatter of the next).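

In the Rattus norvegicus assay, methyl in place of ethoxy on this aromatic carbon gives the first measured size for this change: a number 33 percentage points higher from compound 1 to compound 4 (beyond the scatter). This single swap therefore moves the read-out, whereas in a physicochemical assay for lipophilicity (on this read-out lower numbers stand for lower lipophilicity and higher numbers for higher lipophilicity), compound 1 gives 1.03 and compound 4 gives 1.26, with a number 0.23 log units higher from compound 1 to compound 4 (within the scatter). Nothing available explains the step in the whole-organism read-out.

As far as these compounds go, what an amine or a hydroxyl group on this same aromatic carbon would give remains open. So does whether this step holds when other groups sit on the aromatic ring.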